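From benzyl to 2-methylbenzyl on the shared core

The source may report more compounds than this note shows. Statements on the series, on what has been measured and on what is new or still open speak of the compounds shown alone.

Measured so far in a functional assay on SW480 cells (Homo sapiens) for cytotoxicity, read by MTT assay, with a stated time of 48 h; a higher number here means a weaker inhibitor, a lower number a stronger inhibitor:
compound 1 `O=c1ccoc2cc(OCc3cn(Cc4ccccc4)nn3)ccc12` gives 42900 nM
compound 2 `Cc1ccc(Cn2cc(COc3ccc4c(=O)ccoc4c3)nn2)cc1` gives 10400 nM
compound 3 `O=c1ccoc2cc(OCc3cn(Cc4cccc(Br)c4)nn3)ccc12` gives > 100000 nM as a limit of the assay, not a number

Of the two exact numbers, compound 1 holds the higher, so it is the weaker inhibitor of that pair. Compound 4 `Cc1ccccc1Cn1cc(COc2ccc3c(=O)ccoc3c2)nn1` turns its benzyl into 2-methylbenzyl, with methyl in place of hydrogen on an aromatic carbon, ortho to a large group (methyl in place of hydrogen on an aromatic carbon). The closest measured change also adds a methyl, giving 4-methylphenyl, and shows a 4.1-fold lower number from compound 1 to compound 2 (0.62 log units; beyond the scatter). Adding bromo instead shows an at least 2.3-fold higher number from compound 1 to compound 3 (0.36 log units; beyond the scatter), but that is a different group. With a single methyl step as a guide, and the methyl placed differently, a modest drop is expected, probably smaller than the measured one. The expected step is a 2.1-fold lower number from compound 1 to compound 4 (0.33 log units; beyond the scatter) in this assay. For compound 4 the estimate is 20000 nM, expected to lie between 7000 nM and 60000 nM.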

Compound 4, half-maximal inhibitory concentration: > 100000 nM
Compound 4: no number, only a limit (the forecaster's own chance of this, stated with the estimate: 10%); at least 5.0-fold (0.69 log units) between middle value and limit.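

In this assay, a methyl ortho to a large group does not behave like the methyl of 4-methylphenyl: the number goes the other way, with an at least 2.3-fold higher number from compound 1 to compound 4 (0.36 log units; beyond the scatter). Changing 4-methylphenyl to 2-methylphenyl gives an at least 9.6-fold higher number from compound 2 to compound 4 (0.98 log units; beyond the scatter), so among these compounds the place of the methyl decides the direction of the change. Compound 3 and compound 4 both sit at a limit, so the step between them cannot be read: the limit of > 100000 nM in this assay, at which 2 of the 4 values shown sit.

Going by these compounds, what a methoxy group or an amine would do ortho to a large group stays open. So does the effect of 3-methylphenyl, which would show how a methyl behaves on the third ring position.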